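Acetyl to 2-fluorobenzoyl on a nitro-aryl triazene

This account rests on a few compounds, and the source may have more. Where it says the series, first, only, none or still open, it means among the compounds named here.

Three triazenes have so far been tested in a functional assay on HeLa cells (Homo sapiens) for cytotoxicity, read by MTT assay, with a stated time of 72 h; a higher number here means a weaker inhibitor, a lower number a stronger inhibitor. Compound 2 `O=[N+]([O-])c1ccc(/N=N/Nc2ccc([N+](=O)[O-])cc2Cl)c(Cl)c1` gives 3010 nM, compound 3 `CC(=O)N(/N=N/c1ccc([N+](=O)[O-])cc1Cl)c1ccc([N+](=O)[O-])cc1Cl` gives 630 nM, and compound 1 `O=C(c1ccccc1C(F)(F)F)N(/N=N/c1ccc([N+](=O)[O-])cc1Br)c1ccc([N+](=O)[O-])cc1Br` gives 13300 nM. Compound 3 therefore stands with the lowest number of the three, compound 2 being nearest to it and compound 1 furthest. Within the data shown here, the one step that can be read between single-change neighbours is a 4.8-fold lower number from compound 2 to compound 3 (0.68 log units; beyond the scatter), acetyl in place of hydrogen on a nitrogen on an aromatic ring.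

Compound 4 `O=C(c1ccccc1F)N(/N=N/c1ccc([N+](=O)[O-])cc1Cl)c1ccc([N+](=O)[O-])cc1Cl` differs from compound 3 by 2-fluorophenyl in place of methyl on a carbonyl carbon. Among the measured compounds shown here, no measured pair carries exactly this change, and compound 1 differs from compound 4 in two places, so its value can only be set beside the others as it stands. Compound 4 is expected to give a higher number than compound 3 because compound 1 gives 13300 nM while also carrying an aromatic acyl group. The expected step is a 4.8-fold higher number from compound 3 to compound 4 (0.68 log units; beyond the scatter), and compound 4 is estimated at 3000 nM in this assay, within a range from 800 nM to 12000 nM.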

Compound 4, half-maximal inhibitory concentration: 2350 nM
For compound 4 the middle estimate is 1.3-fold (0.11 log units) above the measured one, within the range that was stated.
By their numbers in this assay, from the lowest: compound 3; then compounds 4 and 2 (each within the scatter of the next); then compound 1.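

In this assay, among these compounds, acylation on this nitrogen had so far been seen only as acetyl, which gave a 4.8-fold lower number from compound 2 to compound 3 (0.68 log units; beyond the scatter). The change of acyl group now shows that this lower number does not hold for every acyl group: 2-fluorophenyl in place of methyl on the carbonyl carbon gives a 3.7-fold higher number from compound 3 to compound 4 (0.57 log units; beyond the scatter). With (2-fluorophenyl)carbonyl on the nitrogen, the number stays level with that of the unacylated compound (a 1.3-fold lower number from compound 2 to compound 4 (0.11 log units; within the scatter)). Nothing available here bears on why the two acyl groups differ.

The compounds shown leave open whether a plain phenyl without the fluorine, or a longer chain such as propyl or butyl on the carbonyl carbon, would stay with methyl or with 2-fluorophenyl. They also leave open how an acyl group carrying an amine or a carboxylic acid would read in this assay.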